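Pyridin-2-yl in Place of 1,3-Thiazol-2-yl at a Dopamine Receptor

This account rests on a few compounds, and the source may have more. Where it says the series, first, only, none or still open, it means among the compounds named here.

Measured compounds:
Compound 1 `Cc1cccc(C(=O)NCN2CCC(c3nccs3)CC2)c1` gives 9.8 nM in a functional assay on HEK293 cells for agonist activity at D(4) dopamine receptor (Homo sapiens), read by FLIPR; a higher number here means that more compound is needed for the effect, a lower number that less compound is needed.
Compound 2 `Cc1cccc(NC(=O)CN2CCC(c3nccs3)CC2)c1` gives 1 nM in this assay.
Compound 3 `Cc1cc(NC(=O)CN2CCC(c3cccc[n+]3[O-])CC2)ccc1F` gives 18 nM in this assay.

Among these three numbers compound 1 stands second highest. Its nearest neighbour is compound 3, whose number is higher but lies within the scatter of repeated measurements, so no order can be read between the two. Compound 2 is the furthest away, with a lower number that lies beyond the scatter. No two of these compounds differ in only one place, so no single structural step has been isolated among them.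

The compound not yet measured is compound 4 `Cc1cccc(C(=O)NCN2CCC(c3ccccn3)CC2)c1`. Relative to compound 1 the change is pyridin-2-yl in place of 1,3-thiazol-2-yl on a saturated ring carbon. Going by the values given here, no measured pair shows this exchange, and the rest of compound 1 is kept unchanged. In this assay the step is expected to be small, in no firm direction and not beyond the scatter, namely a 1.2-fold higher number from compound 1 to compound 4 (0.09 log units; within the scatter). Compound 4 is therefore expected to give about 12 nM, with a range from 4 nM to 40 nM.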

Compound 4, half-maximal effective concentration: 9 nM
Beside the measured number, compound 4's estimate is 1.3-fold (0.12 log units) above it, and the stated range covers the measured number.
By their numbers in this assay, from the lowest: compound 2; then compounds 4, 1 and 3 (each within the scatter of the next).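

In this assay, pyridin-2-yl in place of 1,3-thiazol-2-yl on the saturated ring carbon gives a 1.1-fold lower number from compound 1 to compound 4 (0.04 log units; within the scatter), a step within the scatter, so the two groups cannot be told apart at this position. Going by these compounds alone, this is the first step in the set that isolates a single place, and it shows that, on the core of compound 1, the sulfur of the five-membered ring and its second hetero atom are not needed for a number of this size. No measurement of any property of the two groups bears on this result, so the data offer no explanation for it.

From the compounds shown here alone, it remains open whether the same exchange would be as small on the core of compound 2, which gives 1 nM. Also open, going by these compounds, is how a phenyl ring, a carboxylic acid or an amine would behave on the same ring carbon.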